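Replacing an Imidazolylmethyl Cap with an Acylated Pyrrolidine

The source may hold more compounds than are shown below. What is called first, only, known or untested is meant among the compounds shown, and "the series" means these compounds.

Compound 1 `O=C(Cn1ccnc1)N1CCC(NS(=O)(=O)c2cc(S(=O)(=O)c3ccccc3)ccc2C(F)(F)F)CC1` is measured in a functional assay on U2OS cells for antagonist activity at proto-oncogene Wnt-3 (Homo sapiens), read by a luciferase reporter, with a stated time of 18 h (on this read-out lower numbers stand for an effect already at smaller amounts and higher numbers for an effect only at larger amounts of compound), where it gives 230 nM, the highest of the three numbers seen so far. Compound 2 `CC(C)(C)OC(=O)N1C(=O)CC[C@H]1C(=O)N1CCC(NS(=O)(=O)c2cc(S(=O)(=O)c3ccccc3)ccc2C(F)(F)F)CC1` gives 90 nM in this assay, and compound 3 `CC(C)C(=O)N1CCC[C@H]1C(=O)N1CCC(NS(=O)(=O)c2cc(S(=O)(=O)c3ccccc3)ccc2C(F)(F)F)CC1` gives 90 nM. Compound 4 `CC(C)(C)CC(=O)N1CCC[C@H]1C(=O)N1CCC(NS(=O)(=O)c2cc(S(=O)(=O)c3ccccc3)ccc2C(F)(F)F)CC1` has not yet been measured. It differs from compound 1 in one place: 1-(neopentylcarbonyl)pyrrolidin-2-yl in place of (1H-imidazol-1-yl)methyl on a carbonyl carbon. Within the data shown here, the only measured step that bears directly on this change is a 2.6-fold lower number from compound 1 to compound 3 (0.41 log units; beyond the scatter), where the same pyrrolidin-2-yl ring, carrying an isopropylcarbonyl group rather than a neopentylcarbonyl group, took the place of the same imidazolylmethyl group. Compound 2 carries a different group on that carbonyl carbon, and its value sits with that of compound 3. Because the step of a 2.6-fold lower number from compound 1 to compound 3 (0.41 log units; beyond the scatter) is modest but beyond the scatter, a step of similar size toward lower numbers is expected here. For compound 4 the expected step is a 2.6-fold lower number from compound 1 to compound 4 (0.41 log units; beyond the scatter). Compound 4 is therefore estimated at 90 nM, with a range from 40 nM to 220 nM.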

Compound 4, half-maximal effective concentration: 120 nM
Compound 4: the middle estimate sits 1.3-fold (0.12 log units) below what was measured, and the stated range covers the measured number.
By their numbers in this assay, from the lowest: compounds 2, 3, 4 and 1 (each within the scatter of the next, the first and the last beyond it).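

Placing the neopentylcarbonyl version of the pyrrolidine on this carbonyl carbon gives a 1.9-fold lower number from compound 1 to compound 4 (0.28 log units; within the scatter) and so, unlike the isopropylcarbonyl version, this replacement cannot be told apart from the imidazolylmethyl cap by these numbers. Among these compounds, exchanging isopropyl for neopentyl on the carbonyl carbon of the pyrrolidine acyl group gives a 1.3-fold higher number from compound 3 to compound 4 (0.12 log units; within the scatter) and thus shows that these two groups are not separated on this read-out, which was not visible from the earlier compounds. No independent measurement is available to explain these results.

On these data alone, a pyrrolidine with a free ring amine, or with an acetyl or benzoyl group on its nitrogen, remains open. So does the mirror-image form of the pyrrolidine stereocentre.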